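Sulfonamide aryl swap in a pyrrolidine series

This account rests on a few compounds, and the source may have more. Where it says the series, first, only, none or still open, it means among the compounds named here.

Measured compounds:
- compound 1 `N#Cc1ccc(O[C@H]2CN(S(=O)(=O)c3ccc(Cl)cc3Cl)C[C@@]2(O)CN)cc1F`: 4
- compound 2 `N#Cc1ccc(O[C@H]2CN(S(=O)(=O)c3ccc(Cl)cc3Cl)C[C@]2(O)CO)cc1F`: 4.9

Of the compounds shown here, two of the shared core have been measured in a physicochemical assay for lipophilicity, at pH 7.4; on this read-out lower numbers stand for lower lipophilicity and higher numbers for higher lipophilicity. In this assay compound 1 gives 4, the lower of the two numbers. Compound 2 differs from compound 1 in several places. In this assay compound 2 gives 4.9, a number that lies beyond the scatter above compound 1. Going by the values given here, no single-point step between measured compounds is available, so nothing measured yet tells how a change on the sulfonyl sulfur moves this read-out.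

Compound 3 `N#Cc1ccc(O[C@H]2CN(S(=O)(=O)c3ccc(Cl)cn3)C[C@@]2(O)CN)cc1F` is not yet measured. It differs from compound 1 in one place: 5-chloropyridin-2-yl in place of 2,4-dichlorophenyl on a sulfonyl sulfur. The ring that leaves carries two chlorine atoms and no acceptor; the ring that enters carries one chlorine and one hydrogen-bond acceptor, and has one heavy atom fewer.

For this assay a downward step is expected, beyond the scatter, with the step from compound 1 to compound 3 estimated at a number 1.10 log units lower from compound 1 to compound 3 (beyond the scatter). Compound 3 is accordingly expected to give about 2.9, within a range of 2.2 to 3.6.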

Compound 3, distribution coefficient: 2.5
Estimate against measurement, compound 3: 0.40 log units above, within the range that was stated.
By their numbers in this assay, from the lowest: compound 3; then compound 1; then compound 2.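

In this assay, going by these compounds alone, 5-chloropyridin-2-yl in place of 2,4-dichlorophenyl on a sulfonyl sulfur gives a number 1.50 log units lower from compound 1 to compound 3 (beyond the scatter), the first step that can be read at a single place, and it shows that a change at this position alone can shift the read-out by a large amount. The change is not a single variable: the ring that enters has one chlorine where the ring that leaves has two, along with one hydrogen-bond acceptor and one heavy atom fewer, and this one step cannot divide the shift among those differences. Nothing at hand bears on why the read-out moves with this swap.

Open, from the compounds shown here alone, is whether the shift follows the ring nitrogen or the lost chlorine, which a 4-chlorophenyl group or an unsubstituted pyridin-2-yl group on the sulfonyl sulfur would help to separate. Also open is whether a step of this size carries over to the other substituents on the shared core, since only one pair of compounds shown here differs in one place.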